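The source may report more compounds than this note shows. Statements on the series, on what has been measured and on what is new or still open speak of the compounds shown alone.

Measured compounds in a functional assay on CNE-2 cells (Homo sapiens) for cytotoxicity, read by MTT assay, with a stated time of 72 h; on this read-out higher numbers stand for weaker inhibition and lower numbers for stronger inhibition:
Compound 1, `COc1cc2ncnc(NNC(=S)NC(=O)c3ccc(F)cc3)c2cc1OC`, gives 16100 nM.
Compound 2, `O=C(NC(=S)NNc1ncnc2ccccc12)c1ccc(F)cc1`, gives 2840 nM.

Of these two, compound 2 stands at the lower number, and compound 1 at a clearly higher one; the gap between them lies beyond the usual scatter of this assay, so compound 2 is the stronger inhibitor of the pair. Compound 1 carries two methoxy groups on its shared core, compound 2 carries none there, and both keep the same 4-fluorophenyl amide on the other end.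

Compound 3, `Cc1ccc(C(=O)NC(=S)NNc2ncnc3ccccc23)cc1`, differs from compound 2 in one place: methyl in place of fluoro on an aromatic carbon. The shared core and the thiosemicarbazide linker are unchanged.

Among the measured compounds shown here, no step with this exact change has been measured here, so the expectation rests on the small size of the swap. A single heavy atom is exchanged for another, with no change in ring count, hydrogen-bond donors or acceptors, or charge. The step from compound 2 to compound 3 is expected to be small, most likely within the scatter, and if anything slightly toward a higher number: a 1.2-fold higher number from compound 2 to compound 3 (0.09 log units; within the scatter). Compound 3 is therefore estimated at 3500 nM, within a range of 1200 nM to 10000 nM.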

Compound 3, half-maximal inhibitory concentration: 17200 nM
Compound 3: the middle estimate sits 4.9-fold (0.69 log units) below what was measured; the whole stated range lies below it.
By their numbers in this assay, from the lowest: compound 2; then compounds 1 and 3 (each within the scatter of the next).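

In this assay, the swap from 4-fluorophenyl to 4-methylphenyl gives a 6.1-fold higher number from compound 2 to compound 3 (0.78 log units; beyond the scatter) and so shows that this place on the aromatic ring, para to a large group, responds strongly to what sits on it. The shared core and the thiosemicarbazide linker stay the same across this pair, and the swap exchanges only one heavy atom for another, with no change in ring count or net charge, so even a very small edit at this end of the molecule can move the number beyond the scatter, something compounds 1 and 2 could not show while both carried the same 4-fluorophenyl amide. Nothing available here explains why fluoro and methyl part so clearly on this read-out.

Among the compounds shown here, with only two groups compared at this place, it remains open whether a bare hydrogen, a chloro group, a methoxy group or an amine there would give a number close to that of compound 2 or close to that of compound 3. On these data alone, it also remains open whether the same swap would have a similar effect on the core of compound 1 with its two methoxy groups.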